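The compounds below may be only part of what the source reports. "The series", "measured", "known", "first", "only" and "open" are said of these compounds alone.

Compound 1, whose structure is `CCC[C@@H]1O[C@H](COCc2ccccc2)[C@@H](OCc2ccccc2)[C@H](OCc2ccccc2)[C@@H]1O`, carries a propyl chain on a sugar-like ring that bears three benzyl ether groups and one free hydroxyl. In a functional assay on HL-60 cells (Homo sapiens) for antiproliferative activity, read by MTT assay (on this read-out lower numbers stand for stronger inhibition and higher numbers for weaker inhibition), compound 1 gives "not active" (no number reported), so no number stands for it, only the statement that growth of the cells was not held back. Compound 2, with structure `CCC[C@@H]1O[C@H](COCc2ccccc2)[C@@H](OCc2ccccc2)[C@H](OCc2ccccc2)[C@H]1O`, is its close relative: the fact that compounds 1 and 2 differ only in the configuration as drawn. In this assay compound 2 gives 11700 nM, a weak effect. For the measured compounds named here, these two results are all that is known here, and no step between them has been worked out, so they are taken simply as they stand.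

Compound 3, with structure `CC(C)C[C@@H]1O[C@H](COCc2ccccc2)[C@@H](OCc2ccccc2)[C@H](OCc2ccccc2)[C@@H]1O`, keeps the configuration of compound 1 and changes only the chain: methyl in place of hydrogen on a saturated chain carbon bound to two saturated chain carbons. Such a change adds one carbon to a chain that sits away from the ring. Compound 1 shows no measurable inhibition, and a change of this kind is not expected to move the result by more than the usual scatter, so compound 3 is expected to remain weak, with an estimated value of about 30000 nM, in a range from 8000 nM to 150000 nM, and a fair chance that again only inactivity is reported.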

Compound 3, half-maximal inhibitory concentration: "not active" (no number reported)
For compound 3 the study gives words and no number; no gap can be computed for the estimate.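

For the compounds shown here, compound 1 and compound 3 are both reported only in words, as not active, so no step from one to the other can be read. Nothing given here explains this result. The compounds shown leave open whether changing propyl to isobutyl would alter the activity of compound 2, which alone has a number.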